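A few compounds are considered here, and "the series" means these few. Any claim that something is new, unique, unknown or untested is made for them only; others in the source may bear on it.

Compound 1 `NC(=O)c1cc(-c2ccc(NS(=O)(=O)c3cccc(Cl)c3Cl)cc2)nc2[nH]ncc12` gives 1 nM in an assay for inhibition of serine/threonine-protein kinase Sgk1 (Homo sapiens), with stated times of 30 min and 60 min, in the presence of a further agent that is not named here; on this read-out higher numbers stand for weaker inhibition and lower numbers for stronger inhibition.
Compound 2 `CC(C)NC(=O)c1cc(-c2ccc(NS(=O)(=O)c3cccc(Cl)c3Cl)cc2)nc2[nH]ncc12` gives 68 nM in this assay.
Compound 3 `CN1CCC(CNC(=O)c2cc(-c3ccc(NS(=O)(=O)c4cccc(Cl)c4Cl)cc3)nc3[nH]ncc23)C1` gives 14 nM in this assay.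

Among these three numbers, compound 3 stands second highest. Its nearest neighbour is reached by a 4.9-fold lower number from compound 2 to compound 3 (0.69 log units; beyond the scatter), and its furthest by a 14-fold higher number from compound 1 to compound 3 (1.15 log units; beyond the scatter).

Compound 4 `CCN1CCC(CNC(=O)c2cc(-c3ccc(NS(=O)(=O)c4cccc(Cl)c4Cl)cc3)nc3[nH]ncc23)C1` differs from compound 3 by methyl in place of hydrogen on a saturated chain carbon bound to an amine nitrogen in a ring. Among the measured compounds shown here, every measured step so far, including a 68-fold higher number from compound 1 to compound 2 (1.83 log units; beyond the scatter), changes the group on the amide-type nitrogen; none alters the ring amine where the new methyl enters. For the measured compounds named here, no step bears directly on this change, so no shift beyond the scatter is expected in this assay.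

Compound 4 is therefore expected to give about 14 nM in this assay, with a range from 5 nM to 40 nM.

That estimate means an expected step of no change at the digits printed from compound 3 to compound 4 (within the scatter), within the scatter.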

Compound 4, half-maximal inhibitory concentration: < 1 nM
Compound 4 was reported as a limit; the forecaster's own chance of this, stated with the estimate: 0%; middle value at least 14-fold (1.14 log units) from the limit.
By their numbers in this assay, from the lowest: compound 1; then compound 3; then compound 2.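

Methyl in place of hydrogen on a saturated chain carbon bound to an amine nitrogen in a ring, a place no earlier step touched, gives an at least 14-fold lower number from compound 3 to compound 4 (1.14 log units; beyond the scatter) and so shows that this small change can matter greatly. The group on the amide-type nitrogen also proves able to carry far more than compound 2 suggested, with an at least 68-fold lower number from compound 2 to compound 4 (1.83 log units; beyond the scatter) as the step. Compound 4 gives < 1 nM as a limit of the assay, so a number no higher from compound 1 to compound 4 (the limit leaves the size open) is all that can be read: the limit of < 1 nM in this assay, at which 1 of the 4 values shown sits.

On these data alone, whether a longer chain such as propyl on the ring amine would keep this gain remains open. So does the effect of a cyclopropyl group or an acetyl group there.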